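A few compounds are considered here, and "the series" means these few. Any claim that something is new, unique, unknown or untested is made for them only; others in the source may bear on it.

Compound 1 `C#CCOc1ccc(/C=C/C(=O)c2ccc(Br)cc2)cc1`: 34%
Compound 2 `C#CCOc1ccc(/C=C/C(=O)c2ccc(OC)cc2)cc1`: 27%
Compound 3 `C#CCOc1ccc(/C=C/C(=O)c2ccc([N+](=O)[O-])cc2)cc1`: not yet measured

In a functional assay on A549 cells (Homo sapiens) for inhibition, read by MTT assay, with a stated time of 48 h, tested at 10 uM (on this read-out higher numbers stand for more inhibition of growth at the one concentration tested and lower numbers for less inhibition of growth), compound 2 gives 27%, which lies within the usual scatter of compound 1 at 34%. Going on to compound 3 puts nitro in place of methoxy on an aromatic carbon, para to a large group: nitro in place of methoxy on an aromatic carbon. Going by the values given here, only one measured step bears on this aromatic carbon, a number 7 percentage points lower from compound 1 to compound 2 (within the scatter), and it stays within the scatter. A change beyond the scatter is therefore not expected in this assay. The estimated step is a number 5 percentage points higher from compound 2 to compound 3 (within the scatter), with no firm direction. For compound 3 the expected value is 32%, within an estimated range from 18% to 48%.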

Compound 3, percent growth inhibition at one concentration: 33%
The estimate for compound 3 lay 1 percentage points below the measured number; measured number inside the range.
By their numbers in this assay, from the lowest: compounds 2, 3 and 1 (each within the scatter of the next).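

In this assay, nitro in place of methoxy gives a number 6 percentage points higher from compound 2 to compound 3 (within the scatter) and nitro in place of bromo gives a number 1 percentage points lower from compound 1 to compound 3 (within the scatter) on the same aromatic carbon. This place, para to a large group, has now held three different groups, and all three compounds stay within the scatter of one another, so none of these swaps separates them. No measured evidence here explains why these groups read alike. From the compounds shown here alone, what an amine or a carboxylic acid would give at this place remains open.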